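A few compounds are considered here, and "the series" means these few. Any claim that something is new, unique, unknown or untested is made for them only; others in the source may bear on it.

Compound 1, with the structure `CCCC[C@]1(CC)CS(=O)(=O)c2ccc(N(C)C)cc2[C@@H](c2ccccc2)[C@H]1O`, carries a dimethylamino group on its aromatic ring; in an assay on cells for inhibition of ileal sodium/bile acid cotransporter (Homo sapiens) (a lower number here means a stronger inhibitor, a higher number a weaker inhibitor), compound 1 gives 5 nM. Compound 2, `CCCC[C@]1(CC)CS(=O)(=O)c2ccc(NC(C)=O)cc2[C@@H](c2ccccc2)[C@H]1O`, differs only in having an acetamido group at that position, and in this assay compound 2 gives 90 nM. Going by the values given here, the single measured step, an 18-fold higher number from compound 1 to compound 2 (1.26 log units; beyond the scatter), is large, and compound 2 therefore stands at the weaker end of the two numbers so far, its nearest neighbour being compound 1.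

Compound 3, `CCCCCC(=O)Nc1ccc2c(c1)[C@@H](c1ccccc1)[C@@H](O)[C@](CC)(CCCC)CS2(=O)=O`, grows out of compound 2 by one change: butyl in place of hydrogen on a saturated chain carbon bound to a carbonyl carbon. Among the compounds with values here, no measured step in this set concerns lengthening the chain on the amide carbonyl; the only step, from compound 1 to compound 2, exchanges one whole group for another and so gives little guidance here. With nothing pointing clearly in either direction, the expectation for compound 3 is a number close to that of compound 2, a step of a 1.1-fold lower number from compound 2 to compound 3 (0.05 log units; within the scatter) that may well lie within the scatter. The estimate for compound 3 in this assay is 80 nM, with a range from 25 nM to 300 nM.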

Compound 3, half-maximal inhibitory concentration: 300 nM
Compound 3: middle estimate off by 3.8-fold (0.57 log units), on the low side; measured number inside the range.
By their numbers in this assay, from the lowest: compound 1; then compound 2; then compound 3.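

In this assay, the group carried on the amide carbonyl clearly matters: going from acetamido to (pentylcarbonyl)amino gives a 3.3-fold higher number from compound 2 to compound 3 (0.52 log units; beyond the scatter), a modest step but one beyond the scatter. Measured against the dimethylamino group at the same position, the longer amide gives a 60-fold higher number from compound 1 to compound 3 (1.78 log units; beyond the scatter), so among these three groups the number rises from dimethylamino to acetamido to (pentylcarbonyl)amino, and neither amide comes close to dimethylamino. No measurement shown here gives a reason for these differences.

With only methyl and pentyl on the carbonyl, the compounds cannot show whether the number climbs steadily with chain length, or how a propyl chain or a chain longer than pentyl would fall on that line. As far as these compounds go, it also remains open how a plain amine or a methylamino group would compare with dimethylamino on the aromatic carbon, and whether a carboxylic acid on the amide chain would change the picture.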